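The source may report more compounds than this note shows. Statements on the series, on what has been measured and on what is new or still open speak of the compounds shown alone.

Measured so far: compound 1 `CC(=O)OC/C(=C\c1ccc(Cl)cc1Cl)C(=O)c1ccccc1` gives 3100 nM in a functional assay on HBL-100 cells (Homo sapiens) for inhibition, read by sulforhodamine B assay, with a stated time of 48 h; on this read-out lower numbers stand for stronger inhibition of growth and higher numbers for weaker inhibition of growth; compound 2 `CC(=O)OC/C(=C/c1ccccc1Cl)C(=O)c1ccccc1` gives 21000 nM in this assay.

Compound 2 stands at the highest of the two numbers, so of the two it is the weaker inhibitor of growth; compound 1 lies at a lower number, a gap beyond the scatter. Compound 3 `CC(=O)OC/C(=C/c1ccc(Cl)cc1Cl)C(=O)c1ccccc1` is the next compound to be measured. It differs from compound 2 by chloro in place of hydrogen on an aromatic carbon. Among the compounds with values here, with no measured pair of this kind to lean on, a step toward a lower number, of moderate size and beyond the scatter, is expected. Compound 3 is expected to give about 5000 nM in this assay, within 1500 nM to 15000 nM, a change of a 4.2-fold lower number from compound 2 to compound 3 (0.62 log units; beyond the scatter).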

Compound 3, concentration for 50% growth inhibition: 23000 nM
Compound 3: middle estimate off by 4.6-fold (0.66 log units), on the low side; the whole stated range lies below it.
By their numbers in this assay, from the lowest: compound 1; then compounds 2 and 3 (each within the scatter of the next).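

In this assay, chloro in place of hydrogen at this position, para to a large group, gives a 1.1-fold higher number from compound 2 to compound 3 (0.04 log units; within the scatter), so with the double bond drawn Z this change shows no effect beyond the scatter. Changing the double bond from Z to E, by contrast, corresponds to a 7.4-fold higher number from compound 1 to compound 3 (0.87 log units; beyond the scatter). This gap can be traced to the double bond alone because of one thing: the fact that compounds 1 and 3 differ only in the configuration as drawn

Going by these compounds, whether chloro has any effect when the double bond is drawn E remains open. So does how a methoxy group or an amine at this position would read.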